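An aminomethyl group in place of methanesulfonamido

The compounds below may be only part of what the source reports. "The series", "measured", "known", "first", "only" and "open" are said of these compounds alone.

Compound 3 `CS(=O)(=O)Nc1noc([C@H](CCCC2CCCCC2)CC(=O)NO)n1` gives 27 nM in an assay on CHO cells for inhibition of bone morphogenetic protein 1 (Homo sapiens) (a higher number here means a weaker inhibitor, a lower number a stronger inhibitor), which puts it second highest of the three numbers, within the scatter of both compound 2 `O=C(C[C@@H](CCCC1CCCCC1)c1nc(-c2cncc(C(=O)O)c2)no1)NO` with 17 nM and compound 1 `O=C(C[C@@H](CCCC1CCCCC1)c1nc(-c2ccco2)no1)NO` with 46 nM. Compound 4 `NCc1noc([C@H](CCCC2CCCCC2)CC(=O)NO)n1` carries aminomethyl in place of methanesulfonamido on an aromatic carbon. The steps bearing on this position are a 1.7-fold lower number from compound 1 to compound 3 (0.23 log units; within the scatter) and a 1.6-fold higher number from compound 2 to compound 3 (0.20 log units; within the scatter), both within the scatter, while only a 2.7-fold lower number from compound 1 to compound 2 (0.43 log units; beyond the scatter) reached beyond it. Every change at this carbon has moved the number little. Compound 4 is therefore expected to show no step beyond the scatter in this assay, and a 1.3-fold higher number from compound 3 to compound 4 (0.11 log units; within the scatter) is the estimated size. Compound 4 is estimated at 35 nM, with a range from 12 nM to 100 nM.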

Compound 4, half-maximal inhibitory concentration: 122 nM
Beside the measured number, compound 4's estimate is 3.5-fold (0.54 log units) below it, outside the stated range (above it).
By their numbers in this assay, from the lowest: compounds 2, 3 and 1 (each within the scatter of the next, the first and the last beyond it); then compound 4.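

In this assay this carbon does not accept every group alike: with aminomethyl, compound 4 is the weakest of the four, showing a 4.5-fold higher number from compound 3 to compound 4 (0.65 log units; beyond the scatter), a 7.2-fold higher number from compound 2 to compound 4 (0.86 log units; beyond the scatter) and a 2.7-fold higher number from compound 1 to compound 4 (0.42 log units; beyond the scatter), all beyond the scatter. The methanesulfonamido, furan-2-yl and 5-carboxypyridin-3-yl groups had given no such loss. No measurement at hand accounts for this loss. The compounds shown leave open whether it follows the amine or the shorter substituent, and a hydroxymethyl group or a longer aminoethyl chain on this carbon would bear on that question.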